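This account rests on a few compounds, and the source may have more. Where it says the series, first, only, none or still open, it means among the compounds named here.

Working notes on the series. The shared core appears in compound 1 `CN1CCC[C@@H]1Cn1nc(CC2CCCCC2)c2ccccc2c1=O` with a cyclohexyl group on a saturated chain carbon bound to an aromatic carbon. In an assay for binding affinity to Alpha-1A adrenergic receptor (Homo sapiens) (on this read-out lower numbers stand for stronger inhibition and higher numbers for weaker inhibition), compound 1 returns only a limit of > 1990 nM, not a number. That reading is the one that sits at the limit of > 1990 nM in this assay, at which 1 of the 3 values shown sits. Compound 2 `CN1CCC[C@@H]1Cn1nc(Cc2ccc(F)c(F)c2)c2ccccc2c1=O` carries 3,4-difluorophenyl and gives 200 nM in this assay. Compound 3 `CN1CCC[C@@H]1Cn1nc(CCc2ccccc2)c2ccccc2c1=O` carries benzyl and gives 200 nM in this assay, so compound 3 stands level with compound 2, the nearest value: no change at the digits printed from compound 2 to compound 3 (within the scatter). The two aryl compounds sit well away from the cyclohexyl compound, with an at least 9.9-fold lower number from compound 1 to compound 2 (0.99 log units; beyond the scatter) and an at least 9.9-fold lower number from compound 1 to compound 3 (0.99 log units; beyond the scatter).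

Compound 4 `CN1CCC[C@@H]1Cn1nc(Cc2cccc(F)c2)c2ccccc2c1=O` is not yet measured. It differs from compound 3 in that (3-fluorophenyl in place of benzyl on a saturated chain carbon bound to an aromatic carbon). The step that bears directly on this change is no change at the digits printed from compound 2 to compound 3 (within the scatter), where a fluorinated phenyl and an unsubstituted phenyl in the same place gave the same number. Among the measured compounds shown here, no other measured pair varies the aryl ring. On that basis the expected step in this assay is none beyond the scatter, no change at the digits printed from compound 3 to compound 4 (within the scatter). The estimate for compound 4 in this assay is 200 nM, with a range from 70 nM to 600 nM.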

Compound 4, inhibition constant: 50.1 nM
Compound 4: the middle estimate sits 4.0-fold (0.60 log units) above what was measured; the measured number lies below the stated range.
By their numbers in this assay, from the lowest: compound 4; then compounds 2 and 3 (each within the scatter of the next). At a limit, above all of these: compound 1.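

In this assay, the shared number of compounds 2 and 3 did not mean that this place tolerates any aryl change, since a 4.0-fold lower number from compound 2 to compound 4 (0.60 log units; beyond the scatter), with hydrogen in place of fluoro on an aromatic carbon as the only difference, and the match between the 3,4-difluorophenyl and phenethyl compounds now looks like a coincidence of two different structures rather than a flat region of the series. The step from the phenethyl compound is of the same size, a 4.0-fold lower number from compound 3 to compound 4 (0.60 log units; beyond the scatter), and it also counts as the lowest number of the four, with the gap from the cyclohexyl compound widening to an at least 39-fold lower number from compound 1 to compound 4 (1.59 log units; beyond the scatter). Compound 1 is a limit and not a number, so that last step is a bound only: the limit of > 1990 nM in this assay, at which 1 of the 4 values shown sits.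

The compounds shown do not separate the part of the phenethyl to 3-fluorobenzyl change that comes from the chain from the part that comes from the fluoro group, as both differ in that one step. They also leave open how a chloro group, a methoxy group or a pyridyl ring would read in this place.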